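From Fluoro to Nitro: Estimating One Swap

A few compounds are considered here, and "the series" means these few. Any claim that something is new, unique, unknown or untested is made for them only; others in the source may bear on it.

All values below come from a functional assay on HT-29 cells (Homo sapiens) for inhibition (on this read-out higher numbers stand for weaker inhibition and lower numbers for stronger inhibition), and form the whole of the data.

Compound 1 `COc1cccc2c1[n+]([O-])nc(N)[n+]2[O-]` gives 624000 nM
Compound 2 `Nc1n[n+]([O-])c2c(F)cccc2[n+]1[O-]` gives 8700 nM
Compound 3 `Nc1n[n+]([O-])c2cc(F)ccc2[n+]1[O-]` gives 47800 nM

Compound 3 stands second highest of these three numbers, so it inhibits more weakly than compound 2 and more strongly than compound 1, with both gaps beyond the scatter. The unmeasured compound 4 `Nc1n[n+]([O-])c2cc([N+](=O)[O-])ccc2[n+]1[O-]` differs from compound 3 in a single place. The change is nitro in place of fluoro on an aromatic carbon and amounts to nitro in place of fluoro on an aromatic carbon.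

Within the data shown here, only one measured step bears on this, and only loosely. It is a 72-fold lower number from compound 1 to compound 2 (1.86 log units; beyond the scatter) and is large, with fluoro replacing methoxy. It shows that exchanging a group on an aromatic carbon can shift the number strongly in this assay and that a sizeable step cannot be ruled out here. Among the measured compounds shown here, no measured compound carries nitro, so the direction remains a judgement, and a lower number is the tentative expectation. The expected result is a 3.4-fold lower number from compound 3 to compound 4 (0.53 log units; beyond the scatter) and this is estimated to be smaller than the measured step. For compound 4 the estimate is 14000 nM within an expected range of 3500 nM to 50000 nM and the data support no tighter claim.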

Compound 4, half-maximal inhibitory concentration: 14100 nM
Compound 4: the middle estimate sits 1.0-fold (0.00 log units) below what was measured, and the stated range covers the measured number.
By their numbers in this assay, from the lowest: compounds 2 and 4 (each within the scatter of the next); then compound 3; then compound 1.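

Read in this assay, nitro in place of fluoro gives a 3.4-fold lower number from compound 3 to compound 4 (0.53 log units; beyond the scatter) and this is the only step shown that is taken at this position, the aromatic carbon meta to a fused ring and para to a fused ring. The earlier compounds shown here showed that a swap on an aromatic carbon of this core can move the number, but they said nothing about this carbon, where the step is modest yet still beyond the usual scatter. A group of three heavy atoms with two hydrogen-bond acceptors replaces a single fluorine here without weakening inhibition, and no measurement shown explains why this exchange lowers the number.

As far as these compounds go, with only fluoro and nitro to compare at this position, two points cannot show a trend, and how an amine, a carboxylic acid or a longer chain would behave on this carbon remains unknown. From the compounds shown here alone, it is also open whether nitro would lower the number in the same way on the carbon that bears fluoro in compound 2.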